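This account rests on a few compounds, and the source may have more. Where it says the series, first, only, none or still open, it means among the compounds named here.

In a functional assay on Hep 3B2 cells (Homo sapiens) for cytotoxicity, read by MTT assay (on this read-out lower numbers stand for stronger inhibition and higher numbers for weaker inhibition), compound 1 `COc1ccc(OC)c(C(=O)/C=C/c2ccsc2)c1` gives 5700 nM and compound 2 `COc1ccc(OC)c(C(=O)/C=C/c2sccc2C)c1` gives 16700 nM as the higher of the two numbers, so compound 2 is the weaker of the pair. Compound 3 `COc1ccc(OC)c(C(=O)/C=C/c2occc2Br)c1` keeps the shared core and differs from compound 2 only on a double-bonded chain carbon bound to a double-bonded chain carbon, where 3-bromofuran-2-yl stands in place of 3-methylthiophen-2-yl (3-bromofuran-2-yl in place of 3-methylthiophen-2-yl on a double-bonded chain carbon bound to a double-bonded chain carbon). For the measured compounds named here, the one measured step at this place is a 2.9-fold higher number from compound 1 to compound 2 (0.47 log units; beyond the scatter) for 3-methylthiophen-2-yl in place of thiophen-3-yl, a modest change. Going by the values given here, no measured compound carries 3-bromofuran-2-yl, so that step offers a scale and only a weak hint of direction. Compound 2 with 16700 nM stands at the top of just two numbers, so a move towards a lower number seems the likelier outcome. In this assay a modest step of similar size is therefore expected, estimated as a 2.2-fold lower number from compound 2 to compound 3 (0.35 log units; beyond the scatter) in that direction. For compound 3 the estimated value is 7500 nM within an expected range from 2500 nM to 22000 nM on this thin evidence.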

Compound 3, half-maximal inhibitory concentration: 11000 nM
Compound 3: the middle estimate sits 1.5-fold (0.17 log units) below what was measured; measured number inside the range.
By their numbers in this assay, from the lowest: compounds 1, 3 and 2 (each within the scatter of the next, the first and the last beyond it).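

In this assay the change on a double-bonded chain carbon bound to a double-bonded chain carbon reads as a 1.5-fold lower number from compound 2 to compound 3 (0.18 log units; within the scatter) and as a 1.9-fold higher number from compound 1 to compound 3 (0.29 log units; within the scatter) and so leaves compound 3 within the scatter of both compound 1 and compound 2, although those two stand apart beyond it. This position therefore takes a ring with oxygen as its hetero atom and a bromine on it, and the resulting number cannot be separated from those of the two sulfur-containing rings, so the earlier gap does not mark a simple divide between thiophene-type groups and anything else. Oxygen and bromine enter together while sulfur and the methyl group leave, and compound 3 alone cannot assign the reading to either swap; no measurement at hand accounts for these numbers.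

As far as these compounds go, the separate contributions of the ring oxygen and the bromine remain open, and a furan-2-yl group without bromine or a 3-methylfuran-2-yl group would be needed to separate them. From the compounds shown here alone, how this assay would read an amine or a carboxylic acid at this place also stays open.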